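The source may report more compounds than this note shows. Statements on the series, on what has been measured and on what is new or still open speak of the compounds shown alone.

Compound 1 `C=C1[C@@H](OC(C)=O)C[C@@H]2[C@](C)(COC=O)[C@H](OC(C)=O)CC[C@@]2(C)[C@@H]1C[C@@H](Nc1cccc(F)c1)C1=CCOC1=O`, compound 2 `C=C1[C@@H](OC(C)=O)C[C@@H]2[C@](C)(COC=O)[C@H](OC(C)=O)CC[C@@]2(C)[C@@H]1C[C@@H](Nc1ccc(O)cc1)C1=CCOC1=O` and compound 3 `C=C1[C@@H](OC(C)=O)C[C@@H]2[C@](C)(COC=O)[C@H](OC(C)=O)CC[C@@]2(C)[C@@H]1C[C@@H](Nc1ccc(OC)c(OC)c1)C1=CCOC1=O` share one core and differ only in the ring group on an amine nitrogen. In a functional assay on A549 cells (Homo sapiens) for cytotoxicity, read by sulforhodamine B assay (a higher number here means a weaker inhibitor, a lower number a stronger inhibitor), compound 1 gives 23200 nM and compound 2 gives 29100 nM. The measured step between them is a 1.3-fold higher number from compound 1 to compound 2 (0.10 log units; within the scatter), so these two cannot be told apart. Compound 3 gives > 50000 nM, which is a limit of the assay and not a number.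

Compound 4 `C=C1[C@@H](OC(C)=O)C[C@@H]2[C@](C)(COC=O)[C@H](OC(C)=O)CC[C@@]2(C)[C@@H]1C[C@@H](Nc1ccc(C(=O)O)cc1)C1=CCOC1=O` has 4-carboxyphenyl in place of 3,4-dimethoxyphenyl on an amine nitrogen. Among the compounds with values here, two measured steps concern the group that leaves. One is an at least 2.1-fold higher number from compound 1 to compound 3 (0.33 log units; beyond the scatter), and the other is an at least 1.7-fold higher number from compound 2 to compound 3 (0.23 log units; that floor lies within the scatter). Within the data shown here, both are floors rather than full sizes, and no measured compound carries the group that enters. Compound 2, with 4-hydroxyphenyl, is the nearest by name, so compound 4 is expected to land near compound 2 or somewhat higher. That points to a small move toward a lower number in this assay, or to none beyond the scatter, and compound 4 may also return only a limit. For compound 4 the expected value is 40000 nM, with an estimated range of 18000 nM to 85000 nM. This expectation amounts to an at least 1.2-fold lower number from compound 3 to compound 4 (0.09 log units; that floor lies within the scatter).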

Compound 4, half-maximal inhibitory concentration: > 50000 nM
Compound 4 ended at the assay's limit; the forecaster's own chance of this, stated with the estimate: 50%; middle value at least 1.2-fold (0.09 log units) from the limit.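

At this place on the amine nitrogen, 4-carboxyphenyl now joins 3,4-dimethoxyphenyl at the limit of this assay, so two differently substituted rings give no readable value, while 3-fluorophenyl and 4-hydroxyphenyl both do. Against the 3-fluorophenyl compound, the change is an at least 2.1-fold higher number from compound 1 to compound 4 (0.33 log units; beyond the scatter), whereas carboxy in place of hydroxy on the aromatic carbon gives an at least 1.7-fold higher number from compound 2 to compound 4 (0.23 log units; that floor lies within the scatter), so only the first of these floors clears the scatter and the true size of neither is known. Within the data shown here, no step between compound 3 and compound 4 can be read, because both stop at the same ceiling: the limit of > 50000 nM in this assay, at which 2 of the 4 values shown sit.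

The compounds shown leave open whether the methyl ester or the primary amide of the carboxy group would bring a readable value back, and how far beyond the limit compound 3 and compound 4 really lie. They also leave open whether a plain phenyl ring, with no substituent, would sit with compound 1 and compound 2 or at the limit.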